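Swapping 3,4-dimethoxyphenyl for pyridin-3-yl

The source may hold more compounds than are shown below. What is called first, only, known or untested is meant among the compounds shown, and "the series" means these compounds.

Measured in an ADME assay on HepG2 2.2.15 cells (Homo sapiens) for cytotoxicity; on this read-out higher numbers stand for lower toxicity in this test and lower numbers for higher toxicity in this test:
- Compound 1 `COCC(=O)OCCc1c(-c2ccccc2Cl)c2cc(Cl)ccc2[nH]c1=O`: 74000 nM
- Compound 2 `COc1cccc(/C=C/C(=O)OCCc2c(-c3ccccc3Cl)c3cc(Cl)ccc3[nH]c2=O)c1`: > 1300000 nM (a limit)
- Compound 3 `COc1ccc(/C=C/C(=O)OCCc2c(-c3ccccc3Cl)c3cc(Cl)ccc3[nH]c2=O)cc1OC`: > 1200000 nM (a limit)

Compound 3 stands at a limit, > 1200000 nM, and has no exact number. Compound 2 also gives only a limit, > 1300000 nM. Between these two there is a step that the two limits leave unreadable from compound 2 to compound 3.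

The next structure, compound 4 `O=C(/C=C/c1cccnc1)OCCc1c(-c2ccccc2Cl)c2cc(Cl)ccc2[nH]c1=O`, differs from compound 3 as follows: pyridin-3-yl in place of 3,4-dimethoxyphenyl on a double-bonded chain carbon bound to a double-bonded chain carbon. Pyridin-3-yl takes the place of 3,4-dimethoxyphenyl on a double-bonded chain carbon bound to a double-bonded chain carbon.

Among the compounds with values here, no measured step makes this exact swap, so the evidence is indirect. The large steps came when an ethenyl group with an aromatic ring replaced methoxymethyl: an at least 17-fold higher number from compound 1 to compound 2 (1.24 log units; beyond the scatter), and an at least 16-fold higher number from compound 1 to compound 3 (1.20 log units; beyond the scatter). Compound 4 keeps the 2-substituted ethenyl group and changes only its ring, so a drop back toward compound 1 at 74000 nM is not expected.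

The expected change is an at least 1.2-fold lower number from compound 3 to compound 4 (0.07 log units; that floor lies within the scatter), which is estimated to stay within the scatter, and another limit is quite possible. For compound 4 the estimate is 1000000 nM, with an expected range of 250000 nM to 1500000 nM.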

Compound 4, half-maximal cytotoxic concentration: 39000 nM
For compound 4 the middle estimate is 26-fold (1.41 log units) above the measured one; the whole stated range lies above it.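

In this assay, the ring carried by the ethenyl group turns out to matter a great deal: pyridin-3-yl in place of 3,4-dimethoxyphenyl gives an at least 30-fold lower number from compound 3 to compound 4 (1.48 log units; beyond the scatter), and pyridin-3-yl in place of 3-methoxyphenyl gives an at least 33-fold lower number from compound 2 to compound 4 (1.52 log units; beyond the scatter). The ethenyl group alone therefore does not account for the large steps away from compound 1, since the methoxymethyl and 2-(pyridin-3-yl)ethenyl groups cannot be told apart here: a 1.9-fold lower number from compound 1 to compound 4 (0.28 log units; within the scatter). The values of compound 2 and compound 3 are limits, and nothing measured here says why this ring swap has such a large effect.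

Pyridin-3-yl differs from the two methoxy-bearing rings both in having a ring nitrogen and in lacking methoxy groups, so the compounds shown leave open which of these changes goes with the lower number. A plain phenyl ring on the ethenyl group would help to separate the two, while a pyridin-4-yl ring or a pyridin-3-yl ring carrying a methoxy group would show whether the ring nitrogen is enough on its own.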